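The compounds below may be only part of what the source reports. "The series", "measured", "known", "first", "only" and "open" are said of these compounds alone.

Measured in a functional assay on A549 cells (Homo sapiens) for antiproliferative activity, read by MTT assay, with a stated time of 48 h; on this read-out higher numbers stand for weaker inhibition and lower numbers for stronger inhibition:
Compound 1 `N#CC1=C(N)Oc2c(c3nc4ccccc4nc3c3ccccc23)C12C(=O)N(Cc1cnnn1-c1cccc(Br)c1)c1ccccc12` gives > 50000 nM, which is a limit of the assay and not a number.
Compound 2 `Cc1ccc(-n2nncc2CN2C(=O)C3(C(C#N)=C(N)Oc4c3c3nc5ccccc5nc3c3ccccc43)c3ccccc32)cc1C` gives > 50000 nM, likewise a limit.
Compound 3 `Cc1ccc(-n2nncc2CN2C(=O)C3(C(C#N)=C(N)Oc4c3c3nc5ccccc5nc3c3ccccc43)c3ccccc32)c(C)c1` gives > 50000 nM, likewise a limit.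

Compound 3 therefore stands nowhere on a scale of numbers; it sits at the limit of > 50000 nM in this assay, at which 3 of the 3 values shown sit, together with the two other members of the series. The swaps of the aryl group on the aromatic nitrogen give a step that the two limits leave unreadable from compound 1 to compound 3 and a step that the two limits leave unreadable from compound 2 to compound 3, and both steps are unreadable for the same reason, namely (the limit of > 50000 nM in this assay, at which 3 of the 3 values shown sit).

Compound 4 `N#CC1=C(N)Oc2c(c3nc4ccccc4nc3c3ccccc23)C12C(=O)N(Cc1cnnn1-c1cc(Cl)ccc1Cl)c1ccccc12` is the next member: 2,5-dichlorophenyl in place of 2,4-dimethylphenyl on an aromatic nitrogen. This is the same kind of swap as the two unreadable steps, an exchange of one substituted phenyl for another on the aromatic nitrogen, so they bear on it only in showing that no such exchange has yet moved a value off the limit. No direction or size can be read from them. The step that the limit leaves unreadable from compound 3 to compound 4 is therefore expected to be one that is itself not readable, with compound 4 most likely remaining at the limit in this assay. The estimate for compound 4 in this assay is 80000 nM, with a range from 40000 nM to 200000 nM.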

Compound 4, half-maximal inhibitory concentration: > 50000 nM
Compound 4: only a limit was reported; the forecaster's own chance of this, stated with the estimate: 85%; the middle value does not contradict the limit.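

In this assay compound 4 gives > 50000 nM, a limit of the assay and not a number. No step from compound 1, compound 2 or compound 3 to compound 4 can be read, because all four compounds share one limit: the limit of > 50000 nM in this assay, at which 4 of the 4 values shown sit.

The compounds shown leave open how these four rank against one another and whether any other substituted phenyl on the aromatic nitrogen gives a measurable value.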